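This account rests on a few compounds, and the source may have more. Where it says the series, first, only, none or still open, it means among the compounds named here.

In a functional assay on DMS-114 cells (Homo sapiens) for inhibition, read by colorimetric assay and sulforhodamine B assay, with a stated time of 48 h (a higher number here means a weaker inhibitor of growth, a lower number a stronger inhibitor of growth), compound 1 `CCCCCCCCCCCC[C@@H](O)[C@H]1CC[C@H]([C@H](O)CCCCCCCCCCNC(=O)c2cccs2)O1` gives 282 nM with thiophen-2-yl on the carbonyl carbon. Compound 2 `CCCCCCCCCCCC[C@@H](O)[C@H]1CC[C@H]([C@H](O)CCCCCCCCCCNC(=O)c2ccco2)O1` gives 282 nM with furan-2-yl in that place. Compound 3 `CCCCCCCCCCCC[C@@H](O)[C@H]1CC[C@H]([C@H](O)CCCCCCCCCCNC(=O)c2ccoc2)O1` gives 191 nM with furan-3-yl there and stands within the scatter of the other two. The measured ring swaps show no change at the digits printed from compound 1 to compound 2 (within the scatter) and a 1.5-fold lower number from compound 1 to compound 3 (0.17 log units; within the scatter) and also a 1.5-fold lower number from compound 2 to compound 3 (0.17 log units; within the scatter) as the third step. All three are small.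

Compound 4 `CCCCCCCCCCCC[C@@H](O)[C@H]1CC[C@H]([C@H](O)CCCCCCCCCCNC(=O)c2cncs2)O1` is still unmeasured. It keeps the shared core and has 1,3-thiazol-5-yl in place of furan-3-yl on a carbonyl carbon, and the count of that difference reads 1,3-thiazol-5-yl in place of furan-3-yl on a carbonyl carbon in full. Within the data shown here, no measured compound carries a five-membered aromatic ring with 2 hetero atoms, so no measured step covers this swap directly, and the range is kept wider than the steps seen so far. The closest guide is the swap that ends at compound 3 with a 1.5-fold lower number from compound 1 to compound 3 (0.17 log units; within the scatter) as its size, which also leaves a sulfur-containing ring. On that basis no shift beyond the scatter is expected in this assay. The expected step is a 1.3-fold higher number from compound 3 to compound 4 (0.10 log units; within the scatter) and no more than that. For compound 4 the estimated value is 240 nM with an expected range from 120 nM to 480 nM in this read-out.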

Compound 4, concentration for 50% growth inhibition: 219 nM
Estimate against measurement, compound 4: 1.1-fold (0.04 log units) above, within the range that was stated.
By their numbers in this assay, from the lowest: compounds 3, 4, 1 and 2 (each within the scatter of the next).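

At the place on a carbonyl carbon whose other neighbour is an amide-type nitrogen, the series now includes a five-membered aromatic ring with 2 hetero atoms, and in this assay the steps to 1,3-thiazol-5-yl read a 1.1-fold higher number from compound 3 to compound 4 (0.06 log units; within the scatter) and a 1.3-fold lower number from compound 2 to compound 4 (0.11 log units; within the scatter) and also a 1.3-fold lower number from compound 1 to compound 4 (0.11 log units; within the scatter). The swap from furan-3-yl to 1,3-thiazol-5-yl raises the count of hydrogen-bond acceptors from 1 to 2 without a step beyond the scatter, so across these four compounds neither the number nor the identity of the ring hetero atoms gives a readable difference at this place. Nothing measured here accounts for this lack of separation.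

From the compounds shown here alone, all four compounds carry a five-membered aromatic ring at this place, so it remains open whether a phenyl ring, a saturated piperidine ring, or a ring bearing an amine or a carboxylic acid would also stay within the scatter in this assay. Going by these compounds, it also remains open whether a shorter or longer chain between the shared core and the amide would change the number, as all four compounds share one chain.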